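Inverting the hydroxyl-bearing centre in the pyridinyl series

A few compounds are considered here, and "the series" means these few. Any claim that something is new, unique, unknown or untested is made for them only; others in the source may bear on it.

Compound 1 `CC(=O)NC[C@H]1CN(c2ccc(OC[C@@H](O)CNc3ccccc3)c(F)c2)C(=O)O1`: 124000 nM
Compound 2 `CC(=O)NC[C@H]1CN(c2ccc(OC[C@H](O)CNc3ccccc3)c(F)c2)C(=O)O1`: 296000 nM
Compound 3 `CC(=O)NC[C@H]1CN(c2ccc(OC[C@@H](O)CNc3ccccn3)c(F)c2)C(=O)O1`: 22200000 nM

In a physicochemical assay for solubility, read by HPLC (a higher number here means a more soluble compound, a lower number a less soluble compound), compound 3 gives the highest of the three numbers, standing well above compound 2 and compound 1, as the step of a 180-fold higher number from compound 1 to compound 3 (2.25 log units; beyond the scatter) and the step of a 75-fold higher number from compound 2 to compound 3 (1.88 log units; beyond the scatter) show. Compound 4 `CC(=O)NC[C@H]1CN(c2ccc(OC[C@H](O)CNc3ccccn3)c(F)c2)C(=O)O1` has not yet been measured. It differs from compound 3 as follows: the two compounds have the same atoms and bonds and differ only in configuration as drawn: 1 of 2 stereo elements differ; a stereocentre at a saturated chain carbon is drawn S in compound 3 and R in compound 4. The same change at the same saturated chain carbon has already been measured once, in the pair that carries phenyl on the amine nitrogen: there the step was a 2.4-fold higher number from compound 1 to compound 2 (0.38 log units; beyond the scatter), a modest rise, which rests on (the fact that compounds 1 and 2 differ only in the configuration as drawn). Within the data shown here, that single pair is the only guide available, and it suggests a small increase in this assay rather than no change, though the gap is close to the scatter. On that basis compound 4 is expected to give 40000000 nM, with a likely range from 14000000 nM to 110000000 nM; the step this implies, a 1.8-fold higher number from compound 3 to compound 4 (0.26 log units; within the scatter), is an estimate only.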

Compound 4, solubility: 35100000 nM
The estimate for compound 4 lay 1.1-fold (0.06 log units) above the measured number, and the stated range covers the measured number.
By their numbers in this assay, from the lowest: compound 1; then compound 2; then compounds 3 and 4 (each within the scatter of the next).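

Inverting the hydroxyl-bearing centre gave a 2.4-fold higher number from compound 1 to compound 2 (0.38 log units; beyond the scatter) in the phenyl pair, but in this assay the same inversion in the pyridin-2-yl pair gives a 1.6-fold higher number from compound 3 to compound 4 (0.20 log units; within the scatter) and so shows no change that can be told from scatter: the fact that compounds 3 and 4 differ only in the configuration as drawn. With the R centre as drawn, pyridin-2-yl in place of phenyl on an amine nitrogen comes with a 120-fold higher number from compound 2 to compound 4 (2.07 log units; beyond the scatter) and is large, so the large step seen with the S centre is now seen with both configurations. The step of a 280-fold higher number from compound 1 to compound 4 (2.45 log units; beyond the scatter) is also large, and it too carries the pyridin-2-yl group.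

On these data alone, whether the inversion stays this small with pyridin-3-yl or pyrimidin-2-yl on the amine nitrogen remains open. So does what happens at this saturated chain carbon when a methoxy group stands in place of the hydroxyl.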